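The compounds below may be only part of what the source reports. "The series", "measured", "known", "first", "only" and "open" are said of these compounds alone.

Compound 1 `COc1cc(O)c(C(=O)/C=C/c2ccc(F)cc2)c(OC)c1`: 8800 nM
Compound 2 `COc1cc(OC)c(C(=O)/C=C/c2ccccc2)c(OC)c1`: 9400 nM
Compound 3 `COc1cc(O)c(C(=O)/C=C/c2ccccc2OC)c(OC)c1`: 10500 nM

These three compounds were tested in a functional assay on MCF7 cells (Homo sapiens) for cytotoxicity, with a stated time of 48 h; a lower number here means a stronger inhibitor, a higher number a weaker inhibitor. Compound 2 gives 9400 nM, and this value lies within the usual scatter of the values for both compound 1 and compound 3. No ranking of compound 2 against either of them can therefore be drawn from these numbers.

The next compound to consider is compound 4 `COc1cc(OC)c(C(=O)/C=C/c2ccc(Br)cc2)c(OC)c1`, which is compound 2 with bromo in place of hydrogen on an aromatic carbon. Going by the values given here, no measured pair here differs in just one place, so the size of this change has no direct precedent and any forecast is uncertain. The nearest guide is compound 1, which also carries a halogen and gives 8800 nM, a value within the scatter of compound 2. In this assay, no change beyond the scatter is therefore expected, with at most a slight shift towards a stronger inhibitor. The expected step is a 1.3-fold lower number from compound 2 to compound 4 (0.10 log units; within the scatter). For compound 4 the estimated value is 7500 nM, with an expected range of 3000 nM to 17000 nM.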

Compound 4, half-maximal inhibitory concentration: 9500 nM
The estimate for compound 4 lay 1.3-fold (0.10 log units) below the measured number; low and high end bracket the measured number.
By their numbers in this assay, from the lowest: compounds 1, 2, 4 and 3 (each within the scatter of the next).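

Going by these compounds alone, compound 2 and compound 4 form the first pair here that differs in only one place, so the size of this change can now be read directly. In this assay, bromo in place of hydrogen on an aromatic carbon, para to a large group, gives a 1.0-fold higher number from compound 2 to compound 4 (0.00 log units; within the scatter), so this exchange at this position leaves the cytotoxicity read-out unchanged within the usual scatter of repeated measurements. Nothing shown here offers an explanation for this result.

Going by these compounds, whether this position would tolerate a very different group, such as an amine or a carboxylic acid, remains open. So does whether bromo in place of hydrogen would give a similar step on a core other than that of compound 2.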